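Quinolin-3-yl for pyridin-4-yl on the exocyclic double bond

The compounds below may be only part of what the source reports. "The series", "measured", "known", "first", "only" and "open" are said of these compounds alone.

Among the measured compounds shown here, compound 2 `CN(C)c1ccc(C(=O)OCC2(CO)C/C(=C/c3ccncc3)C(=O)O2)cc1` shows the highest number of the two measured so far: in an assay on cells for displacement of a labelled ligand from Ras guanyl-releasing protein 3 (Homo sapiens) (a higher number here means a weaker inhibitor, a lower number a stronger inhibitor), compound 2 gives 2360 nM, while compound 1 `CN(C)c1ccc(C(=O)OCC2(CO)C/C(=C\c3cnc4ccccc4c3)C(=O)O2)cc1` gives 137 nM, a gap beyond the scatter. Compound 3 `CN(C)c1ccc(C(=O)OCC2(CO)C/C(=C/c3cnc4ccccc4c3)C(=O)O2)cc1` carries quinolin-3-yl in place of pyridin-4-yl on a double-bonded chain carbon bound to a double-bonded ring carbon. Because compound 1 gives 137 nM with the same quinolin-3-yl group, a lower number is expected for compound 3, and the expected step of a 7.9-fold lower number from compound 2 to compound 3 (0.90 log units; beyond the scatter) should exceed the scatter. The estimate for compound 3 in this assay is 300 nM, with a range from 80 nM to 1200 nM.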

Compound 3, inhibition constant in the Ras guanyl-releasing protein 3 assay: 1410 nM
Estimate against measurement, compound 3: 4.7-fold (0.67 log units) below; the whole stated range lies below it.
By their numbers in the Ras guanyl-releasing protein 3 assay, from the lowest: compound 1; then compounds 3 and 2 (each within the scatter of the next).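

In the Ras guanyl-releasing protein 3 assay quinolin-3-yl in place of pyridin-4-yl gives no clear gain with the double bond drawn Z, a 1.7-fold lower number from compound 2 to compound 3 (0.22 log units; within the scatter), while in a physicochemical assay for lipophilicity (on this read-out higher numbers stand for higher lipophilicity and lower numbers for lower lipophilicity), the same change gives a number 1.15 log units higher from compound 2 to compound 3 (beyond the scatter), with compound 2 at 2.07 and compound 3 at 3.22. In the Ras guanyl-releasing protein 3 assay the large step lies instead in the drawn geometry of the double bond, E against Z, a 10-fold higher number from compound 1 to compound 3 (1.01 log units; beyond the scatter). That comparison carries a caution: the fact that one of compounds 1 and 3 is drawn with a defined configuration and the other without, at the place where they differ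

Going by these compounds, it remains open how pyridin-4-yl behaves with the double bond drawn E. It is also open whether an amine on the quinolin-3-yl group would alter the result in the Ras guanyl-releasing protein 3 assay.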